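Nitro Gives Way to Methoxy on the Shared Core

This account rests on a few compounds, and the source may have more. Where it says the series, first, only, none or still open, it means among the compounds named here.

In an ADME assay on HMEC-1 cells (Homo sapiens) for antiproliferative activity (on this read-out lower numbers stand for stronger inhibition and higher numbers for weaker inhibition), compound 1 (`COc1ccc(-c2snnc2-c2cc(OC)c(OC)c(OC)c2)cc1O`) gives 3.9 nM and compound 2 (`COc1ccc(-c2snnc2-c2cc(OC)c(OC)c(OC)c2)cc1[N+](=O)[O-]`) gives 26.4 nM. Compound 2 therefore has the higher of the two numbers and the weaker inhibition of the pair.

Compound 3 (`COc1ccc(-c2snnc2-c2cc(OC)c(OC)c(OC)c2)cc1OC`) carries methoxy in place of nitro on an aromatic carbon, ortho to a methoxy group and meta to a large group: methoxy in place of nitro on an aromatic carbon. Within the data shown here, one measured step bears on this carbon: a 6.8-fold higher number from compound 1 to compound 2 (0.83 log units; beyond the scatter), a modest change beyond the scatter that came with nitro in place of hydroxy. It shows that the group at this carbon can shift the number in this assay. Among the measured compounds shown here, still, no measured compound carries the new methoxy there, so the step offers a sense of size but no firm direction. Only a small upward move is therefore expected, and it may not clear the scatter. The expected change is a 1.3-fold higher number from compound 2 to compound 3 (0.12 log units; within the scatter). For compound 3 the estimated value is 35 nM, with an expected range from 8 nM to 200 nM.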

Compound 3, half-maximal inhibitory concentration: 75.8 nM
Beside the measured number, compound 3's estimate is 2.2-fold (0.34 log units) below it, within the range that was stated.
By their numbers in this assay, from the lowest: compound 1; then compound 2; then compound 3.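

At this carbon, ortho to a methoxy group, compound 3 gives the direction that the earlier pair could not: in this assay the exchange of nitro for methoxy brings a 2.9-fold higher number from compound 2 to compound 3 (0.46 log units; beyond the scatter) and places methoxy on the side of weaker inhibition. Set against the hydroxy of compound 1, putting a methyl on that same oxygen brings a 19-fold higher number from compound 1 to compound 3 (1.29 log units; beyond the scatter) and is the largest step among the three compounds, so this small addition matters more here than the exchange of hydroxy for nitro. The three groups now fall in a clear order at this carbon, with hydroxy giving the strongest inhibition, nitro the middle and methoxy the weakest, and every step between them lies beyond the scatter.

The compounds shown leave open how an amine at this carbon, or a chain longer than the methyl on that oxygen, would read in this assay and whether this order of groups holds on any other core. No measurement available here accounts for the order or for the size of these steps.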